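The source may report more compounds than this note shows. Statements on the series, on what has been measured and on what is new or still open speak of the compounds shown alone.

Measured compounds:
- compound 1, `COc1ccc([C@@H]2C/C(=N/OCc3cn(-c4ccc(C(=O)c5ccccc5)cc4)nn3)c3cc(CC=C(C)C)c(OC)cc3O2)cc1`: 34%
- compound 2, `COc1cc2c(cc1CCC(C)C)C(=O)C[C@@H](c1ccc(O)cc1)O2`: 75%

In a functional assay on A549 cells (Homo sapiens) for inhibition, read by sulforhodamine B assay, with a stated time of 48 h, tested at 50 uM (on this read-out lower numbers stand for less inhibition of growth and higher numbers for more inhibition of growth at the one concentration tested), compound 1 gives 34%, the lower of the two numbers recorded here. Among the measured compounds shown here, compound 2, a compound of quite different build, gives 75% in this assay, a gap that lies beyond the usual scatter; the two values show only that compound 1 inhibits growth less strongly than compound 2 at the one concentration tested.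

Compound 3, `COc1ccc([C@@H]2C/C(=N/OCc3cn(-c4ccc(C(N)=O)cc4)nn3)c3cc(CC=C(C)C)c(OC)cc3O2)cc1`, keeps the core of compound 1 and differs from it in one place: amino in place of phenyl on a carbonyl carbon. For the measured compounds named here, no measured pair shows what a change of this kind does in this assay, so the direction of the step is uncertain; a step no larger than the scatter, in either direction, is expected as a number 2 percentage points lower from compound 1 to compound 3 (within the scatter). Compound 3 is therefore expected to give about 32% in this assay, within a range from 15% to 52%.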

Compound 3, percent growth inhibition at one concentration: 100%
Estimate against measurement, compound 3: 68 percentage points below, and the stated range ends below it.
By their numbers in this assay, from the lowest: compound 1; then compound 2; then compound 3.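

In this assay, among the compounds shown here, the exchange of phenyl for amino on this carbonyl carbon gives a number 66 percentage points higher from compound 1 to compound 3 (beyond the scatter) and so shows that the read-out is highly sensitive to the group at this place, which the earlier compounds could not show. The rest of the structure stays the same across this pair, so the whole step goes with this one exchange: benzoyl gives way to carbamoyl, an aromatic ring of six carbons leaves, and a hydrogen-bond donor enters. No measurement shown here accounts for a step of this size.

On these data alone, with a single pair, it remains open whether the step follows from the arrival of amino or from the departure of phenyl. Methylamino or dimethylamino on this carbonyl carbon, or a carboxylic acid in place of the carbamoyl group, would test how far the result extends.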